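Trifluoromethyl for Dimethylamino on a Urea at the Ceiling

The source may report more compounds than this note shows. Statements on the series, on what has been measured and on what is new or still open speak of the compounds shown alone.

Three ureas sharing one core have been tested in an ADME assay on BJ cells (Homo sapiens) for cytotoxicity, with a stated time of 72 h; a lower number here means that less compound is needed, a higher number that more compound is needed for the effect. Compound 1 `Cc1cc(NC(=O)Nc2ccc(C(=O)O)cc2)c2ccccc2n1` carries a carboxy group on its outer ring. In this assay compound 1 gives > 25000 nM, which is a limit of the assay and not a number. Compound 2 `Cc1cc(NC(=O)Nc2ccc(N(C)C)cc2)c2ccccc2n1` carries a dimethylamino group instead. In this assay compound 2 likewise reaches only a limit, > 25000 nM. Compound 3 `Cc1cc(NC(=O)Nc2cccnc2)c2ccccc2n1` has a different outer ring. In this assay compound 3 also stops at a limit, > 25000 nM.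

For the measured compounds named here, because the limit of > 25000 nM in this assay, at which 3 of the 3 values shown sit, is where every value so far sits, the step that the two limits leave unreadable from compound 1 to compound 2 has no readable size, and compound 2 stands exactly where the two others stand, at the limit.

Compound 4 `Cc1cc(NC(=O)Nc2ccc(C(F)(F)F)cc2)c2ccccc2n1` differs from compound 2 by trifluoromethyl in place of dimethylamino on an aromatic carbon.

Going by the values given here, the only measured step that touches this position gives neither size nor direction, and none of the three compounds shows any effect within the range of this assay. The expectation for compound 4 is therefore that it also stays at the limit. Compound 4 is expected to give 40000 nM in this assay, with a range from 20000 nM to 100000 nM. The expected step that the limit leaves unreadable from compound 2 to compound 4 is accordingly one that lies within the scatter.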

Compound 4, half-maximal effective concentration: > 25000 nM
Compound 4 gave a limit, no number; the forecaster's own chance of this, stated with the estimate: 85%; the middle value does not contradict the limit.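

In this assay compound 4 gives > 25000 nM, which is a limit of the assay and not a number. The steps to compound 4 from compound 1 and from compound 2 therefore cannot be read: the limit of > 25000 nM in this assay, at which 4 of the 4 values shown sit.

The compounds shown leave open how far each one lies beyond that limit, and whether any change on the outer ring alters the read-out.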